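Swapping the silicon chain for a brominated one

A few compounds are considered here, and "the series" means these few. Any claim that something is new, unique, unknown or untested is made for them only; others in the source may bear on it.

Measured compounds:
compound 1 `C[n+]1ccn(COCCC[Si](C)(C)C)c1/C=N/O` with 0.43
compound 2 `COC(=O)CCCCCn1cc[n+](C)c1/C=N/O` with -2.21

The two measured compounds were examined in a physicochemical assay for lipophilicity; a higher number here means a more lipophilic compound, a lower number a more polar compound. Of the two numbers, compound 1 stands highest; its nearest neighbour, compound 2, lies well below it, a gap that is beyond the scatter of this assay.

The unmeasured compound 3 `C[n+]1ccn(COCC(C)(C)CBr)c1/C=N/O` is derived from compound 1 by one change: a group of 5 heavy atoms (4 carbon, 1 bromine; no ring) in place of a group of 6 heavy atoms (5 carbon, 1 silicon; no ring), on a saturated chain carbon bound to an oxygen on a saturated carbon. Among the compounds with values here, no step between measured compounds of this kind is available, so the expectation rests on the structural change alone.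

For compound 3 the author expects a step of a number 0.53 log units lower from compound 1 to compound 3 (beyond the scatter), that is a modest move downward in this assay from compound 1, though one that may not exceed the scatter. The estimate for compound 3 is therefore -0.1, with a range from -0.9 to 0.7.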

Compound 3, distribution coefficient: -0.81
Compound 3: the middle estimate sits 0.71 log units above what was measured; the range from low to high includes it.
By their numbers in this assay, from the lowest: compound 2; then compound 3; then compound 1.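

Within the data shown here, on a saturated chain carbon bound to an oxygen on a saturated carbon, the exchange of the group of 6 heavy atoms (5 carbon, 1 silicon) for the group of 5 heavy atoms (4 carbon, 1 bromine) gives the first one-place step in this assay, with a number 1.24 log units lower from compound 1 to compound 3 (beyond the scatter). The rest of compound 1 is kept in compound 3, so this large step belongs to this one place, and the position is clearly not indifferent to what it carries. Nothing available says which feature of the exchange accounts for the step.

This single step changes the silicon, the bromine and the chain together, and it cannot separate their shares. As far as these compounds go, how a chlorine atom or a hydroxyl group in place of the bromine would stand in this assay remains open.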